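Notes on the aryl substituent of the fused core

This account rests on a few compounds, and the source may have more. Where it says the series, first, only, none or still open, it means among the compounds named here.

Measured so far in a functional assay on A549 cells (Homo sapiens) for antiproliferative activity, read by MTT assay, with a stated time of 72 h; on this read-out higher numbers stand for weaker inhibition and lower numbers for stronger inhibition:
compound 1 `CNC(=O)c1cc(Oc2ccc(NC(=O)c3cc4cccnc4n(-c4ccc(F)cc4)c3=O)cc2)ccn1` gives 110 nM
compound 2 `CNC(=O)c1cc(Oc2ccc(NC(=O)c3cc4cccnc4n(-c4ccc(Br)cc4)c3=O)cc2)ccn1` gives 1050 nM
compound 3 `CCNC(=O)c1cc(Oc2ccc(NC(=O)c3cc4cccnc4n(-c4ccc(F)cc4)c3=O)cc2)ccn1` gives 120 nM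

Compound 3 stands second highest of the three numbers; its gap to compound 1 is within the scatter, as a 1.1-fold higher number from compound 1 to compound 3 (0.04 log units; within the scatter) shows, while compound 2 sits clearly above it. Compound 4 `CCNC(=O)c1cc(Oc2ccc(NC(=O)c3cc4cccnc4n(-c4ccc(Br)cc4F)c3=O)cc2)ccn1` differs from compound 3 by 4-bromo-2-fluorophenyl in place of 4-fluorophenyl on an aromatic nitrogen. The bromo-for-fluoro part of this change has one measured counterpart, a 9.5-fold higher number from compound 1 to compound 2 (0.98 log units; beyond the scatter), a modest step beyond the scatter toward weaker inhibition. For the measured compounds named here, the added fluorine on the entering ring has no measured counterpart, so the expectation rests on that single step alone. A step of about a 7.5-fold higher number from compound 3 to compound 4 (0.88 log units; beyond the scatter) in this assay is therefore expected, toward weaker inhibition. Compound 4 is estimated at 900 nM with a range from 300 nM to 3000 nM in this assay.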

Compound 4, half-maximal inhibitory concentration: 1820 nM
Beside the measured number, compound 4's estimate is 2.0-fold (0.31 log units) below it; low and high end bracket the measured number.
By their numbers in this assay, from the lowest: compounds 1 and 3 (each within the scatter of the next); then compounds 2 and 4 (each within the scatter of the next).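

In this assay, replacing 4-fluorophenyl with 4-bromo-2-fluorophenyl on the aromatic nitrogen gives a 15-fold higher number from compound 3 to compound 4 (1.18 log units; beyond the scatter). The shift toward weaker inhibition seen with the methyl amide pair, a 9.5-fold higher number from compound 1 to compound 2 (0.98 log units; beyond the scatter), therefore also appears with a bromine-bearing aryl group on the ethyl amide, and neither pair goes against it. No available evidence bears on the origin of this step.

The shares of the bromine and the added fluorine in this step remain inseparable. As far as these compounds go, whether a chlorine or a methoxy group in place of the bromine would retain activity also stays open.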